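From 4-hydroxyphenyl to furan-2-yl on a shared core

The compounds below may be only part of what the source reports. "The series", "measured", "known", "first", "only" and "open" are said of these compounds alone.

In a functional assay on HUVEC cells (Homo sapiens) for cytotoxicity (a lower number here means that less compound is needed, a higher number that more compound is needed for the effect), compound 1 (`COC1=C(C)C(=O)/C(=C(O)/C=C/c2ccc(O)cc2)C(=O)C1(C)C`) gives 3.8 ug/mL and stands highest of the two numbers available. Compound 3 (`COC1=C(C)C(=O)/C(=C(O)/C=C/c2cccc3ccccc23)C(=O)C1(C)C`) gives 1.8 ug/mL as the nearest and lower number, a gap that lies beyond the usual scatter. For compound 2 (`COC1=C(C)C(=O)/C(=C(O)/C=C/c2c(C)cc(C)cc2C)C(=O)C1(C)C`) the record shows "not determined" (no result reported) and so adds nothing to the comparison.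

Compound 4 (`COC1=C(C)C(=O)/C(=C(O)/C=C/c2ccco2)C(=O)C1(C)C`) has yet to be measured. Its difference from compound 1 is furan-2-yl in place of 4-hydroxyphenyl on a double-bonded chain carbon bound to a double-bonded chain carbon and it places furan-2-yl in place of 4-hydroxyphenyl on a double-bonded chain carbon bound to a double-bonded chain carbon. Going by the values given here, no measured pair tests this exchange directly, so the expectation rests on thin evidence. Among the compounds with values here, the only numbers on hand are close to each other, with compound 3 at 1.8 ug/mL and compound 1 at 3.8 ug/mL in the same read-out, and this gives no ground for expecting a large move in this assay or for favouring a direction. The estimated step is a 1.1-fold higher number from compound 1 to compound 4 (0.02 log units; within the scatter) and is expected to stay within the scatter. Compound 4 is expected at 4 ug/mL (estimated range 1.5 ug/mL to 11 ug/mL).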

Compound 4, concentration for half-maximal effect: 2.4 ug/mL
For compound 4 the middle estimate is 1.7-fold (0.22 log units) above the measured one, and the stated range covers the measured number.
By their numbers in this assay, from the lowest: compounds 3, 4 and 1 (each within the scatter of the next, the first and the last beyond it).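

Going by these compounds alone, this pair is the first direct test of an exchange at this position on the shared core: in this assay, furan-2-yl in place of 4-hydroxyphenyl on a double-bonded chain carbon bound to a double-bonded chain carbon gives a 1.6-fold lower number from compound 1 to compound 4 (0.20 log units; within the scatter). The leaving group has a six-membered aromatic ring of carbon only and 1 hydrogen-bond donor, while the entering group has a five-membered aromatic ring with 1 hetero atom and 0 hydrogen-bond donors, yet the step stays within the scatter. So, for this one pair, replacing the ring and losing the donor together produce no readable change in this read-out, and no measurement is available to explain that result.

Since the ring and the donor change in the same step, the pair cannot separate what each contributes, and a plain phenyl group would be needed to part them. From the compounds shown here alone, it also remains open whether an amine, a carboxylic acid or a longer chain in place of furan-2-yl would move the number beyond the scatter.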